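A Diethylamino Variant on a Second Core

The compounds below may be only part of what the source reports. "The series", "measured", "known", "first", "only" and "open" are said of these compounds alone.

Of the compounds shown here, three from one series have been measured in a functional assay on Raji cells (Homo sapiens) for antiproliferative activity, read by MTT assay, with a stated time of 48 h (on this read-out lower numbers stand for stronger inhibition and higher numbers for weaker inhibition), and a fourth awaits measurement. Compound 1 `CN(C)CCCCn1c(N)c(-c2nc3cc(Cl)ccc3[nH]2)c2nc(C#N)c(C#N)nc21` and compound 2 `CCN(CC)CCCCn1c(N)c(-c2nc3cc(Cl)ccc3[nH]2)c2nc(C#N)c(C#N)nc21` share one core; compound 3 `CN(C)CCCCn1c(-c2c(N)n(C)c3nc(C#N)c(C#N)nc23)nc2ccccc21` carries a different core, and the difference between the two cores is not broken down here. In this assay compound 1 gives 950 nM, and compound 2 gives 720 nM. The change between them, (diethylamino in place of dimethylamino on a saturated chain carbon, four bonds along the chain from an aromatic nitrogen), produced a 1.3-fold lower number from compound 1 to compound 2 (0.12 log units; within the scatter). In this assay compound 3 gives 1070 nM, which lies within the scatter of the numbers for compound 1 and compound 2, so no ordering among the three is claimed.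

Compound 4 `CCN(CC)CCCCn1c(-c2c(N)n(C)c3nc(C#N)c(C#N)nc23)nc2ccccc21` has not yet been measured. It stands to compound 3 as compound 2 stands to compound 1: the change is diethylamino in place of dimethylamino on a saturated chain carbon, four bonds along the chain from an aromatic nitrogen, the same change at the same place. Since the step from compound 1 to compound 2 stayed within the scatter, the expectation for compound 4 rests on that single precedent and on the value of compound 3. Compound 4 is therefore expected to show a step of about a 1.3-fold lower number from compound 3 to compound 4 (0.10 log units; within the scatter), in line with the step already seen from compound 1 to compound 2. On that basis, compound 4 is estimated at 850 nM in this assay, with a plausible range from 450 nM to 1600 nM.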

Compound 4, half-maximal inhibitory concentration: 600 nM
Compound 4: middle estimate off by 1.4-fold (0.15 log units), on the high side; the measured number falls inside the stated range.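

Carried to the second core, diethylamino in place of dimethylamino on the saturated chain gave a 1.8-fold lower number from compound 3 to compound 4 (0.25 log units; within the scatter) in this assay. Set beside the earlier step on the first core, this result shows no difference that repeated measurement could separate, so on these two cores the change can be said to carry over without a detectable shift in its size: the same change on two cores in this assay, a 1.3-fold lower number (0.12 log units; within the scatter) from compound 1 to compound 2 and a 1.8-fold lower number (0.25 log units; within the scatter) from compound 3 to compound 4, 1.4-fold (0.13 log units) apart, within the scatter of two such steps

It does not show that diethylamino is better than dimethylamino on either core, since each step lies within the scatter on its own and the two steps merely agree in being small, and a pair of cores is too little to establish a rule for the whole series.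

The compounds shown leave open whether a cyclic amine such as piperidine or morpholine, or a primary amine, in place of the diethylamino group would move the number beyond the scatter. They also leave open whether a shorter or longer chain between the aromatic nitrogen and the amine would do so, and whether the agreement between the two steps would hold for such groups.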